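This account rests on a few compounds, and the source may have more. Where it says the series, first, only, none or still open, it means among the compounds named here.

Of the compounds shown here, three sharing one core have been measured in a functional assay on HT-1080 cells (Homo sapiens) for cytotoxicity, read by MTT assay, with a stated time of 72 h; a lower number here means a stronger inhibitor, a higher number a weaker inhibitor. Compound 1 `COc1ccc(/C=C2\CCC/C(=C\c3cccc(OC)c3OC)C2=O)cc1` gives 16300 nM, compound 2 `COc1ccc(/C=C2\CCC/C(=C\c3cccc(OC)c3OC)C2=O)cc1OC` gives 6400 nM, and compound 3 `COc1cc(/C=C2\CCC/C(=C\c3cccc(OC)c3OC)C2=O)ccc1O` gives 5900 nM. Compound 2 stands level with compound 3, with a 1.1-fold lower number from compound 2 to compound 3 (0.04 log units; within the scatter). Compound 1 has the highest number of the three, and the step to the next compound is a 2.5-fold lower number from compound 1 to compound 2 (0.41 log units; beyond the scatter).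

Compound 4 `COc1ccccc1/C=C1\CCC/C(=C\c2ccc(OC)c(OC)c2)C1=O` differs from compound 2 by hydrogen in place of methoxy on an aromatic carbon. Among the compounds with values here, no measured step makes this exact change. The closest evidence is the reverse kind of change, methoxy in place of hydrogen, made on the other aromatic ring in going to compound 2, with a 2.5-fold lower number from compound 1 to compound 2 (0.41 log units; beyond the scatter). The step of a 2.8-fold lower number from compound 1 to compound 3 (0.44 log units; beyond the scatter) also adds oxygen substitution on that same ring and is of similar, modest size. Neither step touches the ring that changes in compound 4, so they offer only a loose guide. A modest rise in the number is therefore expected, and it may not clear the scatter. The estimated size is a 1.4-fold higher number from compound 2 to compound 4 (0.15 log units; within the scatter). Compound 4 is expected at about 9000 nM, with an estimated range from 4000 nM to 20000 nM.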

Compound 4, half-maximal inhibitory concentration: 8100 nM
Estimate against measurement, compound 4: 1.1-fold (0.05 log units) above; low and high end bracket the measured number.
By their numbers in this assay, from the lowest: compounds 3, 2, 4 and 1 (each within the scatter of the next, the first and the last beyond it).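

Within the data shown here, this is the first change on the ring that carries the methoxy group ortho to the one removed, since compounds 1, 2 and 3 differ only on the other aromatic ring, and in this assay the step of a 1.3-fold higher number from compound 2 to compound 4 (0.10 log units; within the scatter) shows that hydrogen and methoxy at this place, meta to a large group, cannot be told apart. The two rings therefore read differently in these few pairs: adding methoxy on the other ring gives a 2.5-fold lower number from compound 1 to compound 2 (0.41 log units; beyond the scatter), a step that clears the scatter, whereas the change on this ring, though opposite in kind, does not. No measurement given here accounts for this result or for the difference between the two rings.

The compounds shown leave open whether any group at this place would move the number, for example an amine, a chlorine atom or a longer chain such as ethoxy. They also leave open what the methoxy group that stays on this ring contributes, as every compound shown keeps it, and whether the same reading would hold outside this single cell assay.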